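Sulfonamide nitrogen substituent series, isopropyl to cyclopentyl

A few compounds are considered here, and "the series" means these few. Any claim that something is new, unique, unknown or untested is made for them only; others in the source may bear on it.

Compound 1 `COCCN(Cc1ccc(C(=O)NO)cc1)S(=O)(=O)c1cc(F)c(F)c(F)c1F` gives only a limit in an assay on Sf9 cells for inhibition of histone deacetylase 8 (Homo sapiens), read by fluorescence and mobility shift assay (on this read-out lower numbers stand for stronger inhibition and higher numbers for weaker inhibition), reading > 1000 nM. Compound 2 `CC(C)N(Cc1ccc(C(=O)NO)cc1)S(=O)(=O)c1cc(F)c(F)c(F)c1F` likewise gives only a limit in this assay, reading > 1000 nM. The step that the two limits leave unreadable from compound 1 to compound 2 therefore cannot be read, since both values sit at the same limit (the limit of > 1000 nM in this assay, at which 2 of the 2 values shown sit). Compound 3 `O=C(NO)c1ccc(CN(C2CCCC2)S(=O)(=O)c2cc(F)c(F)c(F)c2F)cc1` carries the change (cyclopentyl in place of isopropyl on a sulfonamide nitrogen). No readable measured step bears on this change, so nothing beyond the scatter can be foreseen in this assay, and a further limit is the likeliest outcome. Compound 3 is expected near 2500 nM, in the range 600 nM to 10000 nM. The expected step is a step that the limit leaves unreadable from compound 2 to compound 3.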

Compound 3, half-maximal inhibitory concentration: > 1000 nM
Compound 3 was reported as a limit (the forecaster's own chance of this, stated with the estimate: 75%); the middle value does not contradict the limit.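

No new step can be read among compound 1, compound 2 and compound 3 in this assay, and all three values are limits: the limit of > 1000 nM in this assay, at which 3 of the 3 values shown sit.

The compounds shown leave open how 2-methoxyethyl, isopropyl and cyclopentyl on the sulfonamide nitrogen rank against one another.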